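Capping the Hydroxyl of Compound 3 with a Methyl

A few compounds are considered here, and "the series" means these few. Any claim that something is new, unique, unknown or untested is made for them only; others in the source may bear on it.

Three compounds share one core and differ only in the group at the end of a saturated chain on an aromatic nitrogen. Compound 1 `CCCn1c(=O)n(C)c(=O)c2c1ncn2CCC(=O)O` carries a carboxy group; in an assay on Cerebral cortex for binding affinity to adenosine receptor A1 (Cavia porcellus), read by radioligand binding (on this read-out higher numbers stand for weaker inhibition and lower numbers for stronger inhibition), compound 1 gives only a limit of the assay, > 200000 nM. Compound 2 `CCCn1c(=O)n(C)c(=O)c2c1ncn2CCN(C)C` carries a dimethylamino group, and in this assay compound 2 likewise reaches only a limit, > 200000 nM. Within the data shown here, compound 3 `CCCn1c(=O)n(C)c(=O)c2c1ncn2CCO` carries a hydroxy group, and in this assay compound 3 gives 41400 nM, the only number among the three. Compound 1 and compound 2 both sit at a limit of the assay (the limit of > 200000 nM in this assay, at which 2 of the 3 values shown sit). The step of an at least 4.8-fold lower number from compound 1 to compound 3 (0.68 log units; beyond the scatter) and the step of an at least 4.8-fold lower number from compound 2 to compound 3 (0.68 log units; beyond the scatter) are both at least modest, while the step that the two limits leave unreadable from compound 1 to compound 2 cannot be read between the two limits. Compound 4 `CCCn1c(=O)n(C)c(=O)c2c1ncn2CCOC` differs from compound 3 by methyl in place of hydrogen on an oxygen on a saturated carbon. Among the measured compounds shown here, none of the measured steps touches this change: each swaps one chain-end group for another rather than putting a methyl on the oxygen. The expected step of a 1.1-fold higher number from compound 3 to compound 4 (0.04 log units; within the scatter) in this assay is therefore small, within the scatter or little beyond it. Compound 4 is estimated at 45000 nM, between 15000 nM and 150000 nM.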

Compound 4, inhibition constant: 12400 nM
Estimate against measurement, compound 4: 3.6-fold (0.56 log units) above; measured number outside the range, below it.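

In this assay, methyl in place of hydrogen on the oxygen gives a 3.3-fold lower number from compound 3 to compound 4 (0.52 log units; beyond the scatter), so the hydrogen of the hydroxy group is not required at this chain end, and capping it goes with stronger inhibition. Methoxy is now the strongest of the four chain-end groups shown, with an at least 16-fold lower number from compound 2 to compound 4 (1.20 log units; beyond the scatter) and an at least 16-fold lower number from compound 1 to compound 4 (1.20 log units; beyond the scatter). Both of these steps start from a limit of the assay, so their true sizes stay unfixed: the limit of > 200000 nM in this assay, at which 2 of the 4 values shown sit.

On these data alone, what remains open is whether the trend continues with a larger group on the oxygen, such as ethyl or benzyl, or whether methyl is already the best fit. It is also unclear how a longer chain carrying the same methoxy would read.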